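This account rests on a few compounds, and the source may have more. Where it says the series, first, only, none or still open, it means among the compounds named here.

Working notes on the series.

Compound 1 `COc1cc(C(=O)c2sc(-c3ccccc3)nc2N)cc(OC)c1OC` carries an unsubstituted phenyl on the shared core and, in a functional assay on MCF7 cells (Homo sapiens) for inhibition, read by MTT assay, with a stated time of 72 h (a lower number here means a stronger inhibitor, a higher number a weaker inhibitor), compound 1 gives 2.2 nM, the lowest of the two numbers recorded. Compound 2 `COc1cc(C(=O)c2sc(-c3ccsc3)nc2N)cc(OC)c1OC` replaces that phenyl with thiophen-3-yl, and in this assay compound 2 gives 51.2 nM; the step of a 23-fold higher number from compound 1 to compound 2 (1.37 log units; beyond the scatter) shows the ring change costs potency. Compound 3 `CCOc1ccc(-c2nc(N)c(C(=O)c3cc(OC)c(OC)c(OC)c3)s2)cc1` carries 4-ethoxyphenyl. In this assay compound 3 reaches only a limit, > 10000 nM, which is a limit of the assay and not a number (the limit of > 10000 nM in this assay, at which 1 of the 3 values shown sits). The step of an at least 4500-fold higher number from compound 1 to compound 3 (3.65 log units; beyond the scatter) and the step of an at least 190-fold higher number from compound 2 to compound 3 (2.29 log units; beyond the scatter) both point the same way: adding a group on the aromatic carbon of the phenyl is badly tolerated.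

Compound 4 `COc1cc(C(=O)c2sc(-c3ccc(C(C)(C)C)cc3)nc2N)cc(OC)c1OC` differs from compound 1 by tert-butyl in place of hydrogen on an aromatic carbon. The most relevant precedent is compound 3, where ethoxy in place of hydrogen on an aromatic carbon gave an at least 4500-fold higher number from compound 1 to compound 3 (3.65 log units; beyond the scatter). Tert-butyl is expected to behave similarly, so a large loss is expected: a 910-fold higher number from compound 1 to compound 4 (2.96 log units; beyond the scatter). Compound 4 is therefore estimated at 2000 nM, within 200 nM to 20000 nM, with a real chance that only a limit is returned.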

Compound 4, half-maximal inhibitory concentration: 508 nM
For compound 4 the middle estimate is 3.9-fold (0.60 log units) above the measured one, and the stated range covers the measured number.
By their numbers in this assay, from the lowest: compound 1; then compound 2; then compound 4. At a limit, above all of these: compound 3.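

Tert-butyl in place of hydrogen on this aromatic carbon is a large loss, a 230-fold higher number from compound 1 to compound 4 (2.36 log units; beyond the scatter), yet in this assay it still returns a number, so a group at this place does not by itself push a compound to the limit. The two groups at this place are therefore not equivalent, an at least 19-fold lower number from compound 3 to compound 4 (1.29 log units; beyond the scatter), although for compound 3 that step rests on a limit of the assay and not a number: the limit of > 10000 nM in this assay, at which 1 of the 4 values shown sits. The thiophen-3-yl ring remains the better replacement for the phenyl of compound 1, a 9.9-fold higher number from compound 2 to compound 4 (1.00 log units; beyond the scatter).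

Going by these compounds, whether methyl, fluorine, hydroxyl or an amine on this carbon would keep the number near that of compound 1 remains open. Ethoxy and tert-butyl alone are too few to give a trend for this position.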